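Difluorophenyl Replacement on an Anilino-Pyridine Thiazolidinone Series

The compounds below may be only part of what the source reports. "The series", "measured", "known", "first", "only" and "open" are said of these compounds alone.

Compound 1 `CCn1c(=O)/c(=C2\Sc3ccccc3N2C)s/c1=C\c1ccncc1Nc1ccccc1F`: 300 nM in a functional assay on CWR22R cells (Homo sapiens) for inhibition; on this read-out higher numbers stand for weaker inhibition and lower numbers for stronger inhibition
Compound 2 `CCn1c(=O)/c(=C2\Sc3ccccc3N2C)s/c1=C\c1ccncc1Nc1ccccc1C`: 470 nM in this assay
Compound 3 `CCn1c(=O)/c(=C2\Sc3ccccc3N2C)s/c1=C\c1ccncc1Nc1ccccc1Cl`: 460 nM in this assay

Compound 3 stands second highest of the three numbers, and all three lie within the scatter of one another: a 1.5-fold higher number from compound 1 to compound 3 (0.19 log units; within the scatter) and a 1.0-fold lower number from compound 2 to compound 3 (0.01 log units; within the scatter). Compound 4 `CCn1c(=O)/c(=C2\Sc3ccccc3N2C)s/c1=C\c1ccncc1Nc1cc(F)ccc1F` differs from compound 3 by 2,5-difluorophenyl in place of 2-chlorophenyl on a nitrogen on an aromatic ring. Among the compounds with values here, the step that bears on it is the one that swaps the halogen on this ring, a 1.5-fold higher number from compound 1 to compound 3 (0.19 log units; within the scatter), which was within the scatter; nothing measured here carries a second fluorine. Compound 4 is therefore expected to sit close to compound 3, with at most a small step toward lower numbers, a 1.3-fold lower number from compound 3 to compound 4 (0.12 log units; within the scatter). The estimate for compound 4 in this assay is 350 nM, within 150 nM to 800 nM.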

Compound 4, half-maximal inhibitory concentration: 1100 nM
Compound 4: middle estimate off by 3.1-fold (0.50 log units), on the low side; the measured number lies above the stated range.
By their numbers in this assay, from the lowest: compounds 1, 3 and 2 (each within the scatter of the next); then compound 4.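

Swapping among fluoro, methyl and chloro on this ring stayed within the scatter, but adding a second fluorine does not: in this assay the step is a 3.7-fold higher number from compound 1 to compound 4 (0.56 log units; beyond the scatter), with fluoro in place of hydrogen on an aromatic carbon. The 2,5-difluorophenyl group also gives higher numbers than the two other single-substituent groups, with a 2.4-fold higher number from compound 3 to compound 4 (0.38 log units; beyond the scatter) and a 2.3-fold higher number from compound 2 to compound 4 (0.37 log units; beyond the scatter). Nothing available explains this weaker inhibition.

On these data alone, only the 2,5-difluorophenyl group carries a second substituent, so whether another placement of that fluorine would behave alike remains open. As far as these compounds go, how a methoxy group or an amine on this ring would read also remains open.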